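The source may hold more compounds than are shown below. What is called first, only, known or untested is meant among the compounds shown, and "the series" means these compounds.

Measured in a functional assay on M21 cells (Homo sapiens) for antiproliferative activity, read by sulforhodamine B assay, with a stated time of 48 h; a higher number here means a weaker inhibitor, a lower number a stronger inhibitor:
- Compound 1 `Cc1ccccc1OS(=O)(=O)c1ccc(N2CCN(C)C2=O)cc1`: 2900 nM
- Compound 2 `CCN1CCN(c2ccc(S(=O)(=O)Oc3ccc(OC)c(OC)c3)cc2)C1=O`: 35000 nM
- Compound 3 `CCCN1CCN(c2ccc(S(=O)(=O)Oc3ccccc3C)cc2)C1=O`: > 100000 nM

For compound 3 the result is a limit and not a number: the limit of > 100000 nM in this assay, at which 1 of the 3 values shown sits. Compound 4 `CCCN1CCN(c2ccc(S(=O)(=O)Oc3cccc(F)c3)cc2)C1=O` has 3-fluorophenyl in place of 2-methylphenyl on an oxygen.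

Going by the values given here, the only measured step, an at least 34-fold higher number from compound 1 to compound 3 (1.53 log units; beyond the scatter), was large. It lies elsewhere on the molecule, however, and compound 1 and compound 3 both carry 2-methylphenyl, so it does not measure the present change. Compound 4 keeps the part of compound 3 that this step altered, so it is expected to remain a weak inhibitor. Compound 2 carries a different group on that oxygen and still gives a measurable 35000 nM, which leaves room for a modest move towards a lower number. The expected change is an at least 2.0-fold lower number from compound 3 to compound 4 (0.30 log units; that floor lies within the scatter), although it may also end at the limit. For compound 4 the estimate is 50000 nM, with an expected range of 15000 nM to 100000 nM.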

Compound 4, half-maximal inhibitory concentration: 12000 nM
Compound 4: middle estimate off by 4.2-fold (0.62 log units), on the high side; the whole stated range lies above it.
By their numbers in this assay, from the lowest: compound 1; then compound 4; then compound 2. At a limit, above all of these: compound 3.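

In this assay, the group on the oxygen bound to the sulfonyl sulfur can change the result on its own: with the rest of the molecule unchanged, the swap gives an at least 8.3-fold lower number from compound 3 to compound 4 (0.92 log units; beyond the scatter). Going by these compounds alone, the earlier step altered a different part of the molecule, so this is the only measured change at this place. It also shows that compound 4 keeps a measurable value even though it retains the chain of compound 3. The step gives only a minimum size, because the value of compound 3 is a limit and not a number: the limit of > 100000 nM in this assay, at which 1 of the 4 values shown sits.

The swap removes a methyl and adds a fluorine at once, so the compounds shown cannot tell which of the two matters. Going by these compounds, it also remains open what 2-fluorophenyl or unsubstituted phenyl would give on this oxygen, with the rest of compound 4 kept.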